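The source may hold more compounds than are shown below. What is called first, only, known or untested is meant among the compounds shown, and "the series" means these compounds.

Three compounds share one core and carry two hydroxyphenyl groups together with a thiophen-3-yl group. Compound 1 `Oc1cccc(-c2cc(-c3ccsc3)cc(-c3cccc(O)c3)n2)c1` gives 59.2% in an assay on isolated protein for inhibition of DNA topoisomerase 1 (Homo sapiens), with a stated time of 30 min, tested at 100 uM; on this read-out higher numbers stand for a stronger effect at the one concentration tested and lower numbers for a weaker effect. Compound 2 `Oc1ccc(-c2cc(-c3ccsc3)cc(-c3cccc(O)c3)n2)cc1` gives 17.1% in this assay, and compound 3 `Oc1ccc(-c2cc(-c3ccsc3)cc(-c3ccc(O)cc3)n2)cc1` gives 61.7%. Compound 2 stands lowest of the three; the step of a number 42.1 percentage points lower from compound 1 to compound 2 (beyond the scatter) and the step of a number 44.6 percentage points higher from compound 2 to compound 3 (beyond the scatter) both concern a 4-hydroxyphenyl in place of a 3-hydroxyphenyl on an aromatic carbon, and both are large.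

Compound 4 `Oc1ccc(-c2cc(-c3cccnc3)cc(-c3cccc(O)c3)n2)cc1` arises from compound 2 by a change of a different kind: pyridin-3-yl in place of thiophen-3-yl on an aromatic carbon. None of the measured steps touches the thiophen-3-yl group, so there is nothing among these compounds that tells how such a swap moves the read-out in this assay. The only anchor is therefore the value of compound 2 itself, which is the lowest of the three.

For compound 4 the expected step from compound 2 is a number 4.9 percentage points higher from compound 2 to compound 4 (within the scatter), that is, no change beyond the scatter with a wide allowance either way. Compound 4 is thus estimated at 22% in this assay, within a range from 0% to 55%.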

Compound 4, a percentage reported as inhibition, at one concentration (the size of the read-out at that concentration, not a potency): 5.9%
Estimate against measurement, compound 4: 16.1 percentage points above, and the stated range covers the measured number.
By their numbers in this assay, from the lowest: compound 4; then compound 2; then compounds 1 and 3 (each within the scatter of the next).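

For the compounds shown here, the earlier compounds changed only where the hydroxyl groups sit, so this is the first step at the position opposite the ring nitrogen. In this assay, pyridin-3-yl in place of thiophen-3-yl gives a number 11.2 percentage points lower from compound 2 to compound 4 (beyond the scatter), which shows that the group at this position also moves the read-out, though this modest step is set against the large steps seen for the hydroxyphenyl groups. No measurement shown here accounts for this step.

Going by these compounds alone, the swap alters ring size and hetero atom together, and it is seen only on the hydroxyphenyl pattern of compound 2, so it remains open whether it would act alike on the patterns of compound 1 and compound 3. Going by these compounds, how a plain phenyl ring, a furan-3-yl ring or an amine at this position would read also remains open.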